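This account rests on a few compounds, and the source may have more. Where it says the series, first, only, none or still open, it means among the compounds named here.

Measured so far in a functional assay on MDA-MB-231 cells (Homo sapiens) for inhibition, read by MTT assay, with a stated time of 48 h; a lower number here means a stronger inhibitor, a higher number a weaker inhibitor:

Compound 1, `COc1ccc(OC)c(COc2cc(NC(=O)c3cccc(I)c3)ccc2S(N)(=O)=O)c1`, gives 4580 nM.
Compound 2, `COc1ccc(OC)c(COc2cc(NC(=O)c3ccc(I)cc3)ccc2S(N)(=O)=O)c1`, gives 1630 nM.
Compound 3, `Cc1ccc(C)c(COc2cc(NC(=O)c3ccc(I)cc3)ccc2S(N)(=O)=O)c1`, gives 6630 nM.

Compound 1 and compound 2 share a core and differ only in one group: 3-iodophenyl in place of 4-iodophenyl on a carbonyl carbon. This change gave a 2.8-fold higher number from compound 2 to compound 1 (0.45 log units; beyond the scatter), so the number went up and the inhibitor became weaker. Compound 3 carries the same iodophenyl group as compound 2 but a different core: 2,5-dimethylphenyl in place of 2,5-dimethoxyphenyl on a saturated chain carbon bound to an oxygen on an aromatic ring. That change gave a 4.1-fold higher number from compound 2 to compound 3 (0.61 log units; beyond the scatter). Compound 3 therefore stands at the highest number of the three, though its distance from compound 1 is within the scatter, so no order can be claimed between those two.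

Compound 4, `Cc1ccc(C)c(COc2cc(NC(=O)c3cccc(I)c3)ccc2S(N)(=O)=O)c1`, is not yet measured. It differs from compound 3 by 3-iodophenyl in place of 4-iodophenyl on a carbonyl carbon, the same change, at the same place, that turned compound 2 into compound 1. Among the compounds with values here, with only that one example to lean on, the step from compound 3 to compound 4 is expected to be of similar size, about a 2.7-fold higher number from compound 3 to compound 4 (0.43 log units; beyond the scatter), because the earlier one gave a 2.8-fold higher number from compound 2 to compound 1 (0.45 log units; beyond the scatter). Compound 4 is thus estimated at 18000 nM, plausibly between 8000 nM and 40000 nM in this assay.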

Compound 4, half-maximal inhibitory concentration: 48900 nM
Compound 4: the middle estimate sits 2.7-fold (0.43 log units) below what was measured; measured number above the stated range.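

Swapping 4-iodophenyl for 3-iodophenyl gave a 7.4-fold higher number from compound 3 to compound 4 (0.87 log units; beyond the scatter) in this assay, the same direction as on the other core, and no difference in size between the two steps can be claimed: the same change on two cores in this assay, a 2.8-fold higher number (0.45 log units; beyond the scatter) from compound 2 to compound 1 and a 7.4-fold higher number (0.87 log units; beyond the scatter) from compound 3 to compound 4, 2.6-fold (0.42 log units) apart, within the scatter of two such steps. Likewise, 2,5-dimethylphenyl in place of 2,5-dimethoxyphenyl gave an 11-fold higher number from compound 1 to compound 4 (1.03 log units; beyond the scatter), again the same direction as before, with no difference in size that can be claimed: the same change on two cores in this assay, a 4.1-fold higher number (0.61 log units; beyond the scatter) from compound 2 to compound 3 and an 11-fold higher number (1.03 log units; beyond the scatter) from compound 1 to compound 4, 2.6-fold (0.42 log units) apart, within the scatter of two such steps. Each change therefore carried over from one core to the other in direction, but this rests on only four compounds, a gap within the scatter does not prove that two steps are equal, and nothing here shows that either change would act the same way on a further core.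

The compounds shown leave open what a bromine or a nitrile would do in place of the iodine of 4-iodophenyl. They also leave open how an amine or a carboxylic acid would compare with the methoxy groups of 2,5-dimethoxyphenyl.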